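Nitrooxy for Methyl and Cytotoxicity on Liver Cells

The source may hold more compounds than are shown below. What is called first, only, known or untested is meant among the compounds shown, and "the series" means these compounds.

Measured compounds:
compound 1, `Cc1ccc(S(=O)(=O)N2C/C(=C\c3ccccc3F)C(=O)/C(=C/c3ccccc3F)C2)cc1`, 16700 nM
compound 2, `O=C1/C(=C/c2ccccc2F)CN(S(=O)(=O)c2ccc(O[N+](=O)[O-])cc2)C/C1=C\c1ccccc1F`, 15500 nM
compound 3, `Cc1ccc(S(=O)(=O)N2C/C(=C\c3cccc(F)c3)C(=O)/C(=C/c3cccc(F)c3)C2)cc1`, 15700 nM

All three compounds were tested in an ADME assay on L02 cells (Homo sapiens) for cytotoxicity, read by MTT assay, with a stated time of 24 h (a higher number here means a weaker inhibitor, a lower number a stronger inhibitor), where compound 1 gives 16700 nM. Compound 2 is compound 1 with one group exchanged on its aromatic ring: nitrooxy in place of methyl on an aromatic carbon. The change moved the number only slightly, a 1.1-fold lower number from compound 1 to compound 2 (0.03 log units; within the scatter), so the two compounds cannot be told apart in this assay.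

Compound 3 has the same atoms as compound 1 but joined differently; the difference between the two cores is not broken down here. In this assay compound 3 gives 15700 nM, which lies within the scatter of both compound 1 and compound 2.

Compound 4, `O=C1/C(=C/c2cccc(F)c2)CN(S(=O)(=O)c2ccc(O[N+](=O)[O-])cc2)C/C1=C\c1cccc(F)c1`, has not yet been measured. It stands to compound 3 as compound 2 stands to compound 1: nitrooxy in place of methyl on an aromatic carbon. The surroundings of the exchanged group read the same in both pairs, so this is the same change made on a second core.

Going by the values given here, the only guide to compound 4 is the step already seen, and that step was flat. The expected step in this assay is therefore small, a 1.1-fold lower number from compound 3 to compound 4 (0.03 log units; within the scatter), resting on the earlier step from compound 1 to compound 2, a 1.1-fold lower number from compound 1 to compound 2 (0.03 log units; within the scatter), and on the value of compound 3, 15700 nM. Compound 4 is accordingly estimated at 14500 nM, with a likely range from 8000 nM to 26000 nM.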

Compound 4, half-maximal inhibitory concentration: 10700 nM
Beside the measured number, compound 4's estimate is 1.4-fold (0.13 log units) above it; the measured number falls inside the stated range.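

Exchanging methyl for nitrooxy on the second core gives a 1.5-fold lower number from compound 3 to compound 4 (0.17 log units; within the scatter) in this assay, so this pair cannot be told apart, any more than the first pair could. Set side by side, the two steps do not differ: the same change on two cores in this assay, a 1.1-fold lower number (0.03 log units; within the scatter) from compound 1 to compound 2 and a 1.5-fold lower number (0.17 log units; within the scatter) from compound 3 to compound 4, 1.4-fold (0.13 log units) apart, within the scatter of two such steps. On these two cores, then, the exchange carries over in the sense that it leaves no step beyond the scatter in either case, but this does not show that the exchange has no effect at all, as a small real shift could lie hidden within the scatter, and two cores are too few to speak for the whole series.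

The compounds shown leave open whether the same flat result would hold with a chlorine or a methoxy group in place of the fluorine on the two fluorine-bearing rings. They also leave open whether a different group in place of the methyl on the sulfonyl-bearing ring, such as an amine or a carboxylic acid, would move the number in this assay any more than nitrooxy does.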